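The source may hold more compounds than are shown below. What is called first, only, known or untested is meant among the compounds shown, and "the series" means these compounds.

Working notes on the series. Compound 1 `CCCCCCCCCCCCCCNC(=O)[C@@H](NC(=O)/C=C/c1ccccc1)[C@@H](C)O` is the reference point; in a functional assay on A-431 cells (Homo sapiens) for cytotoxicity, read by MTT assay, with a stated time of 48 h (a higher number here means a weaker inhibitor, a lower number a stronger inhibitor), compound 1 gives 64900 nM. Compound 2 `C/C=C/C=C/C(=O)N[C@H](C(=O)NCCCCCCCCCCCCCC)[C@@H](C)O` carries prop-1-en-1-yl in place of phenyl on a double-bonded chain carbon bound to a double-bonded chain carbon. In this assay compound 2 gives > 200000 nM, which is a limit of the assay and not a number. The step of an at least 3.0-fold higher number from compound 1 to compound 2 (0.48 log units; beyond the scatter) is therefore known only as a bound because the limit of > 200000 nM in this assay, at which 1 of the 3 values shown sits, is reached. Compound 3 `CCCCCCCCCCCCCCCCCCNC(=O)[C@@H](NC(=O)/C=C/c1ccccc1)[C@@H](C)O` differs from compound 1 by butyl in place of hydrogen on a saturated chain carbon, ten or more bonds along the chain from an amide-type nitrogen; in this assay compound 3 gives 177000 nM, the step being a 2.7-fold higher number from compound 1 to compound 3 (0.44 log units; beyond the scatter).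

Compound 4 `C/C=C/C=C/C(=O)N[C@H](C(=O)NCCCCCCCCCCCCCCCCCC)[C@@H](C)O` is not yet measured. Relative to compound 3 it carries prop-1-en-1-yl in place of phenyl on a double-bonded chain carbon bound to a double-bonded chain carbon, the same change as that from compound 1 to compound 2, at the same place. Since compound 3 already stands at 177000 nM and the earlier change gave an at least 3.0-fold higher number from compound 1 to compound 2 (0.48 log units; beyond the scatter), compound 4 is expected to give a higher number still, with an estimated step of a 2.8-fold higher number from compound 3 to compound 4 (0.45 log units; beyond the scatter). The estimate for compound 4 is 500000 nM, between 200000 nM and 1500000 nM.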

Compound 4, half-maximal inhibitory concentration: 187000 nM
For compound 4 the middle estimate is 2.7-fold (0.43 log units) above the measured one; the whole stated range lies above it.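

In this assay, the change of phenyl to prop-1-en-1-yl gives a 1.1-fold higher number from compound 3 to compound 4 (0.02 log units; within the scatter), so the size of this step does not carry from the core of compound 1 to the core of compound 3: the same change on two cores in this assay, an at least 3.0-fold higher number (0.48 log units; beyond the scatter) from compound 1 to compound 2 and a 1.1-fold higher number (0.02 log units; within the scatter) from compound 3 to compound 4, at least 2.9-fold (0.46 log units) apart, beyond the scatter of two such steps
The added butyl stretch of chain likewise gives an at least 1.0-fold lower number from compound 2 to compound 4 (0.02 log units; that floor lies within the scatter), which does not match its earlier step: the same change on two cores in this assay, a 2.7-fold higher number (0.44 log units; beyond the scatter) from compound 1 to compound 3 and an at least 1.0-fold lower number (0.02 log units; that floor lies within the scatter) from compound 2 to compound 4, at least 2.9-fold (0.46 log units) apart, beyond the scatter of two such steps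
Compound 2 stands at a limit of the assay, so both gaps are known only as floors, and these compounds give no reason for them: the limit of > 200000 nM in this assay, at which 1 of the 4 values shown sits.

Open, on these data alone, is whether the phenyl change behaves the same way on a shorter chain, such as a decyl chain. Also open, as far as these compounds go, is how an amine or a carboxylic acid at the end of the chain would read.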